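Swapping a fluorophenyl for pyrimidinyl on the cyclopropane

A few compounds are considered here, and "the series" means these few. Any claim that something is new, unique, unknown or untested is made for them only; others in the source may bear on it.

Measured compounds:
compound 1 `CO[C@H](C)[C@H](N)CN(C(=O)[C@@H]1C[C@H]1c1ccccc1)c1ccc(-c2ccccc2)cc1` – 0.68 nM
compound 2 `CCC(CC)C(N)CCN(C(=O)[C@@H]1C[C@H]1c1ccccc1)c1ccc(-c2ccccc2)cc1` – 2 nM
compound 3 `CC[C@H](C)[C@H](N)CN(C(=O)[C@@H]1C[C@H]1c1cccc(F)c1)c1ccc(-c2ccccc2)cc1` – 560 nM

All three were tested in a functional assay for agonist activity at G protein-coupled receptor 88 (Homo sapiens), read by HTRF and cAMP accumulation; on this read-out higher numbers stand for an effect only at larger amounts of compound and lower numbers for an effect already at smaller amounts. Compound 3 stands at the highest number of the three: its value lies a long way from compound 2 and further still from compound 1, both gaps beyond the scatter. For the measured compounds named here, the only measured step between neighbours, a 2.9-fold higher number from compound 1 to compound 2 (0.47 log units; beyond the scatter), is a modest change at the saturated chain carbon bound to the amide-type nitrogen.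

Compound 4 `CC[C@H](C)[C@H](N)CN(C(=O)[C@@H]1C[C@H]1c1ncccn1)c1ccc(-c2ccccc2)cc1` keeps the whole of compound 3 except the aromatic ring on the three-membered carbon ring: pyrimidin-2-yl in place of 3-fluorophenyl on a saturated ring carbon. The change sits on a saturated ring carbon of that three-membered non-aromatic ring. Going by the values given here, no measured pair differs at this position alone; compound 1 and compound 2 carry an unsubstituted phenyl there but differ from compound 3 in the amine-bearing chain as well, so the effect of the ring swap cannot be read from them. Among the compounds with values here, the one measured step concerns a different place and does not bear on it.

With nothing to lean on, the expected step of a 1.4-fold higher number from compound 3 to compound 4 (0.15 log units; within the scatter) is estimated as none beyond the scatter. Compound 4 is therefore expected to give about 800 nM in this assay, within a range from 200 nM to 3500 nM.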

Compound 4, half-maximal effective concentration: 130 nM
Compound 4: the middle estimate sits 6.2-fold (0.79 log units) above what was measured; the whole stated range lies above it.
By their numbers in this assay, from the lowest: compound 1; then compound 2; then compound 4; then compound 3.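

In this assay, for the compounds shown here, the exchange of 3-fluorophenyl for pyrimidin-2-yl on a saturated ring carbon gives a 4.3-fold lower number from compound 3 to compound 4 (0.63 log units; beyond the scatter) and so provides the first direct reading at this place, a modest step but one beyond the scatter. It shows that the aromatic ring on the three-membered ring is not a silent part of these molecules: what it carries moves the number, and with this amine-bearing chain a ring with two hetero atoms gives a lower number than the fluorinated carbon ring. No evidence is at hand that explains this shift, so the gain stays an observation about this one pair.

The compounds shown do not separate the loss of the fluorine from the entry of the two ring nitrogens, a question that unsubstituted phenyl or pyridin-2-yl on this same chain could help to settle. They also leave open whether pyrimidin-2-yl would lower the number to a similar extent on the chains of compound 1 and compound 2, which already sit far lower with their unsubstituted phenyl.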